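The source may report more compounds than this note shows. Statements on the series, on what has been measured and on what is new or still open speak of the compounds shown alone.

Compound 1, with structure `O=C1CC(c2ccc(Br)cc2)Nc2c(Br)cc(Br)cc21`, gives 151 nM in a functional assay on MCF7 cells (Homo sapiens) for inhibition, read by sulforhodamine B assay, with a stated time of 48 h; on this read-out lower numbers stand for stronger inhibition of growth and higher numbers for weaker inhibition of growth.
Compound 2, with structure `O=C1CC(c2ccc([N+](=O)[O-])cc2)Nc2c(Br)cc(Br)cc21`, reaches only the limit < 100 nM in this assay.
Compound 3, with structure `COc1ccc(C2CC(=O)c3cc(Br)cc(Br)c3N2)cc1`, reaches only the limit > 100000 nM in this assay.

Compound 3 thus stands at the weak end of the three measured compounds, where the read-out gives no number but only a limit (the limit of > 100000 nM in this assay, at which 1 of the 3 values shown sits). Both steps into it are large: an at least 660-fold higher number from compound 1 to compound 3 (2.82 log units; beyond the scatter) and an at least 1000-fold higher number from compound 2 to compound 3 (3.00 log units; beyond the scatter), each far beyond the scatter. Compound 4, with structure `O=C1CC(c2ccc(O)cc2)Nc2c(Br)cc(Br)cc21`, has not yet been measured. It differs from compound 3 by hydrogen in place of methyl on an oxygen on an aromatic ring. Going by the values given here, no measured step touches that oxygen, so the two large steps into compound 3 say only that the methoxy compound is weak; they do not tell how removing the methyl will act. Compound 4 is therefore expected to stay near the weak end, with a wide range, and its step of an at least 2.5-fold lower number from compound 3 to compound 4 (0.39 log units; beyond the scatter) is estimated only loosely. Compound 4 is estimated at 40000 nM, between 3000 nM and 150000 nM, with a fair chance that this assay again reports only a limit.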

Compound 4, concentration for 50% growth inhibition: < 100 nM
Compound 4 was reported as a limit; the forecaster's own chance of this, stated with the estimate: 45%; at least 400-fold (2.60 log units) between middle value and limit.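

Taking the methyl off the oxygen on the aromatic ring, the methoxy to hydroxy change, gives an at least 1000-fold lower number from compound 3 to compound 4 (3.00 log units; beyond the scatter) in this assay and is the first measured step at that oxygen; it shows that the weak result of compound 3 does not extend to a free hydroxy at this place. The value of compound 4 is a limit and not a number: the limit of < 100 nM in this assay, at which 2 of the 4 values shown sit. Hydroxy in place of bromo on the aromatic carbon gives an at least 1.5-fold lower number from compound 1 to compound 4 (0.17 log units; that floor lies within the scatter) and so sets no order, while the nitro to hydroxy step cannot be read at all.

From the compounds shown here alone, what stays open is how far the strength of the hydroxy and nitro compounds reaches, as their limits give no number, and whether the methyl itself or any group on that oxygen carries the loss, which an ethoxy or a longer chain there would test. Nor do the compounds shown tell whether an amine or a carboxylic acid in place of the hydroxy would hold the same level of growth inhibition.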